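This account rests on a few compounds, and the source may have more. Where it says the series, first, only, none or still open, it means among the compounds named here.

Measured in a functional assay on ileum for inhibition of histamine H1 receptor (Cavia porcellus); on this read-out higher numbers stand for weaker inhibition and lower numbers for stronger inhibition:
compound 1 `CCSCCn1c(N2CCN(C)CC2)nc2ccccc21`: 19 nM
compound 2 `CCCCCN1CCCN(c2nc3ccccc3n2CCOCC)CC1`: 7.4 nM

On these two numbers compound 1 stands highest; compound 2 sits lower by an amount beyond the usual scatter, but the two structures differ in more than one place, so no single step can be read from that pair. Compound 3 `CN1CCN(c2nc3ccccc3n2CCOCCO)CC1` differs from compound 1 in one place: 2-hydroxyethoxy in place of ethylsulfanyl on a saturated chain carbon, two bonds along the chain from an aromatic nitrogen. For the measured compounds named here, no measured pair shows this change, so the step of a 1.6-fold higher number from compound 1 to compound 3 (0.20 log units; within the scatter) is an expectation only, set at no change beyond the scatter with wide uncertainty. Compound 3 is estimated at 30 nM, range 8 nM to 110 nM.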

Compound 3, half-maximal inhibitory concentration: 42 nM
Beside the measured number, compound 3's estimate is 1.4-fold (0.15 log units) below it; the range from low to high includes it.
By their numbers in this assay, from the lowest: compound 2; then compound 1; then compound 3.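

In this assay, 2-hydroxyethoxy in place of ethylsulfanyl on a saturated chain carbon, two bonds along the chain from an aromatic nitrogen, gives a 2.2-fold higher number from compound 1 to compound 3 (0.34 log units; beyond the scatter). This position therefore responds to the change, modestly and towards weaker inhibition. The step rests on a single pair, and no evidence at hand bears on its cause.

Still open, as far as these compounds go, is whether the step follows the loss of sulfur or the gain of the terminal hydroxyl, as both changes arrive together here. A terminal methoxy or an amine on the same chain would help separate them.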